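Ester chain variants of a cyclopentenone series

A few compounds are considered here, and "the series" means these few. Any claim that something is new, unique, unknown or untested is made for them only; others in the source may bear on it.

Three esters of one shared core have been measured. Compound 1 `CC/C=C\C[C@H]1C(=O)C=C[C@H]1CC(=O)OCCCC` gives 23000 nM in a functional assay on RAW264.7 cells (Mus musculus) for inhibition, read by ELISA, with a stated time of 24 h; a higher number here means that more compound is needed for the effect, a lower number that less compound is needed. Compound 2 `CC/C=C\C[C@H]1C(=O)C=C[C@H]1CC(=O)OCCCCC` gives 25000 nM in this assay, and the step of a 1.1-fold higher number from compound 1 to compound 2 (0.04 log units; within the scatter) corresponds to methyl in place of hydrogen on a saturated chain carbon, four bonds along the chain from an oxygen next to a carbonyl group. Compound 3 `CC/C=C\C[C@H]1C(=O)C=C[C@H]1CC(=O)OC(C)C` gives 20000 nM in this assay; the step of a 1.2-fold lower number from compound 1 to compound 3 (0.06 log units; within the scatter) corresponds to isopropyl in place of butyl on an oxygen next to a carbonyl group, and the step of a 1.3-fold lower number from compound 2 to compound 3 (0.10 log units; within the scatter) leaves compound 3 alongside the other two rather than apart from them.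

Compound 4 `CC/C=C\C[C@H]1C(=O)C=C[C@H]1CC(=O)OC(C)CC` is not yet measured. It differs from compound 3 by methyl in place of hydrogen on a saturated chain carbon, two bonds along the chain from an oxygen next to a carbonyl group. The same kind of change has been made once already, from compound 1 to compound 2 as methyl in place of hydrogen on a saturated chain carbon, four bonds along the chain from an oxygen next to a carbonyl group, where the methyl enters four bonds along the chain from an oxygen next to a carbonyl group rather than two bonds along it; that earlier step was a 1.1-fold higher number from compound 1 to compound 2 (0.04 log units; within the scatter). The two starting points differ by isopropyl in place of butyl on an oxygen next to a carbonyl group. On this basis the expected step is a 1.1-fold higher number from compound 3 to compound 4 (0.02 log units; within the scatter), kept within the scatter because the earlier step of a 1.1-fold higher number from compound 1 to compound 2 (0.04 log units; within the scatter) stayed within it. Compound 4 is therefore estimated at 21000 nM in this assay, with a likely range of 12000 nM to 38000 nM.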

Compound 4, half-maximal effective concentration: 22000 nM
Compound 4: the middle estimate sits 1.0-fold (0.02 log units) below what was measured; the measured number falls inside the stated range.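

The step of a 1.1-fold higher number from compound 3 to compound 4 (0.04 log units; within the scatter) matches the earlier one in this assay: the same change on two cores in this assay, a 1.1-fold higher number (0.04 log units; within the scatter) from compound 1 to compound 2 and a 1.1-fold higher number (0.04 log units; within the scatter) from compound 3 to compound 4, 1.0-fold (0.01 log units) apart, within the scatter of two such steps. With a 1.1-fold lower number from compound 2 to compound 4 (0.06 log units; within the scatter) and a 1.0-fold lower number from compound 1 to compound 4 (0.02 log units; within the scatter) also within the scatter, the four esters stand together, and methyl in place of hydrogen on the ester chain carries from one ester to the other as a step too small to read. Among the compounds shown here, the agreement rests on only two steps, both within the scatter, so it does not show how the change would carry over where it gave a step beyond the scatter, nor how it would behave elsewhere on the shared core.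

From the compounds shown here alone, all four compounds are simple saturated esters of the shared core, so a carboxylic acid, an amide, a benzyl ester or a much longer chain in that place remains open. Also open, going by these compounds, is whether any change away from the ester chain gives a step beyond the scatter in this assay.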